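The compounds below may be only part of what the source reports. "The series", "measured", "known", "first", "only" and "open" are said of these compounds alone.

Measured compounds:
- compound 1 `COc1cc(-c2cc(/C=C/C(=O)c3ccc(Cl)c(Cl)c3)[nH]n2)cc(OC)c1OC`, which in a functional assay on 786-0 cells (Homo sapiens) for cytotoxicity, read by sulforhodamine B assay, with a stated time of 48 h, tested at 0.01 uM (on this read-out lower numbers stand for a stronger effect and higher numbers for a weaker effect at the one concentration tested), gives 95%
- compound 2 `COc1ccc(-c2cc(/C=C/C(=O)c3ccc(N)cc3)[nH]n2)cc1OC`, which in this assay gives 91%

On these two numbers compound 1 stands together with compound 2, the gap between them lying within the usual scatter, so neither can be set apart from the other. Compound 3 `COc1cc(-c2cc(/C=C/C(=O)c3ccc(F)c(F)c3)[nH]n2)cc(OC)c1OC` has not been measured. It differs from compound 1 in one place: 3,4-difluorophenyl in place of 3,4-dichlorophenyl on a carbonyl carbon. Going by the values given here, no step between measured compounds is available to guide this change. The expectation for compound 3 is therefore a step of a number 2 percentage points lower from compound 1 to compound 3 (within the scatter) that stays within the scatter, in neither direction. Compound 3 is expected to give 93%, with a range from 80% to 104%.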

Compound 3, a percentage reported as activity, at one concentration (the size of the read-out at that concentration, not a potency): 95%
Estimate against measurement, compound 3: 2 percentage points below; the range from low to high includes it.
By their numbers in this assay, from the lowest: compounds 2, 1 and 3 (each within the scatter of the next).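

In this assay, placing 3,4-difluorophenyl in place of 3,4-dichlorophenyl on a carbonyl carbon gives no change at the digits printed from compound 1 to compound 3 (within the scatter). Going by these compounds alone, this is the first step read at this position, and it shows that exchanging these two dihalogenated phenyl groups leaves the read-out indistinguishable at the one concentration tested. No measurement is available that bears on the reason for this result. From the compounds shown here alone, whether an amine or a carboxylic acid on this phenyl group would shift the read-out remains open, as does the outcome at any other concentration.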